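Replacing Sulfanyl by Propoxy: An Expected Gain in Activity

This account rests on a few compounds, and the source may have more. Where it says the series, first, only, none or still open, it means among the compounds named here.

Of the compounds shown here, three sharing one core have been tested in a functional assay (spleen, spleen) for activation, with Mus musculus as the target; on this read-out higher numbers stand for an effect only at larger amounts of compound and lower numbers for an effect already at smaller amounts. Compound 1 `CCCCCNc1nc(N)c2nc(O)n(Cc3ccccc3)c2n1` gives 0.1 uM, compound 2 `CCc1nc(N)c2nc(O)n(Cc3ccccc3)c2n1` gives 1 uM, and compound 3 `Nc1nc(S)nc2c1nc(O)n2Cc1ccccc1` gives 10 uM. Compound 3 therefore shows the highest number of the three: the steps of a 100-fold higher number from compound 1 to compound 3 (2.00 log units; beyond the scatter) and a 10-fold higher number from compound 2 to compound 3 (1.00 log units; beyond the scatter) are both beyond the scatter, so compound 3 is the least active of the measured set.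

Compound 4 `CCCOc1nc(N)c2nc(O)n(Cc3ccccc3)c2n1` has not yet been measured. It differs from compound 3 in one place: propoxy in place of sulfanyl on an aromatic carbon. The measured steps show that the group on this carbon matters greatly. The step of a 10-fold higher number from compound 2 to compound 3 (1.00 log units; beyond the scatter) shows that a short carbon chain in place of sulfanyl lowers the number, and a 100-fold higher number from compound 1 to compound 3 (2.00 log units; beyond the scatter) shows that a longer chain attached through a heteroatom lowers it much further. Propoxy, a chain of three carbons attached through an oxygen, sits in character between these two groups, so a clear drop is expected, roughly a 33-fold lower number from compound 3 to compound 4 (1.52 log units; beyond the scatter), landing in the range spanned by compound 2 and compound 1. Compound 4 is therefore estimated to give about 0.3 uM, with a range from 0.05 uM to 2 uM.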

Compound 4, minimum effective concentration: 0.01 uM
The estimate for compound 4 lay 30-fold (1.48 log units) above the measured number; measured number below the stated range.
By their numbers in this assay, from the lowest: compound 4; then compound 1; then compound 2; then compound 3.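

In this assay the propoxy group on this aromatic carbon, between two ring nitrogen atoms, gives the largest step seen at this position (a 1000-fold lower number from compound 3 to compound 4 (3.00 log units; beyond the scatter)). Propoxy also surpasses the two other groups, with a large step against ethyl (a 100-fold lower number from compound 2 to compound 4 (2.00 log units; beyond the scatter)) and a modest one against pentylamino (a 10-fold lower number from compound 1 to compound 4 (1.00 log units; beyond the scatter)), so compound 4 has the lowest number of the four. Among compounds 1 to 3 the number fell as the group grew from sulfanyl through ethyl to pentylamino, but compound 4 goes against any simple rule that a longer chain is better.

Ethoxy, butoxy or propylamino at this carbon would help separate the effect of chain length from that of the linking atom. No measurement here explains why the change from sulfanyl to propoxy is so large.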